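Acrylamide in Place of Chlorobutanamide in Antiproliferative Anilides

This account rests on a few compounds, and the source may have more. Where it says the series, first, only, none or still open, it means among the compounds named here.

Measured so far:
Compound 1 `CC(C)(C)c1ccc(NC(=O)CCCCl)cc1`: > 100000 nM
Compound 2 `CCCCC(O)c1cccc(NC(=O)CCCCl)c1`: > 100000 nM
Compound 3 `C=CC(=O)Nc1ccc(C(C)(C)C)cc1`: 22000 nM

All three were tested in a functional assay on M21 cells (Homo sapiens) for antiproliferative activity, with a stated time of 48 h; on this read-out higher numbers stand for weaker inhibition and lower numbers for stronger inhibition. For compound 1 the value > 100000 nM is a limit of the assay, not a number. Compound 2 likewise gives only a limit, > 100000 nM. Compound 3 gives 22000 nM in this assay. The change vinyl in place of 3-chloropropyl on a carbonyl carbon produced an at least 4.5-fold lower number from compound 1 to compound 3 (0.65 log units; beyond the scatter); since the starting point sits at the limit of > 100000 nM in this assay, at which 2 of the 3 values shown sit, the true size of that drop is not known.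

Compound 4 `C=CC(=O)Nc1cccc(C(O)CCCC)c1` has not yet been measured. Among the measured compounds shown here, it differs from compound 2 by vinyl in place of 3-chloropropyl on a carbonyl carbon, the same change as the one from compound 1 to compound 3. The difference between the two cores of compound 1 and compound 2 is not broken down here.

In this assay the expected step is an at least 3.3-fold lower number from compound 2 to compound 4 (0.52 log units; beyond the scatter). This rests on the step of an at least 4.5-fold lower number from compound 1 to compound 3 (0.65 log units; beyond the scatter), and on compound 2 sitting at the limit of > 100000 nM in this assay, at which 2 of the 3 values shown sit, so only a lower bound for the drop is known. Compound 4 is expected to give 30000 nM, with a likely range from 8000 nM to 100000 nM.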

Compound 4, half-maximal inhibitory concentration: 98000 nM
The estimate for compound 4 lay 3.3-fold (0.51 log units) below the measured number, within the range that was stated.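

Compound 2 gives > 100000 nM in this assay, and this is a limit of the assay, not a number. As far as these compounds go, putting vinyl in place of 3-chloropropyl on the carbonyl carbon gives an at least 1.0-fold lower number from compound 2 to compound 4 (0.00 log units; that floor lies within the scatter), so the change is compatible with a drop on this core too, but the real size of that drop stays unknown, and the printed floor alone does not prove one. What the two cores do share is that each vinyl compound yields a measured number while its 3-chloropropyl partner sits at the limit, yet the data cannot say whether the change is worth the same on both cores: the same change on two cores in this assay, an at least 4.5-fold lower number (0.65 log units; beyond the scatter) from compound 1 to compound 3 and an at least 1.0-fold lower number (0.00 log units; that floor lies within the scatter) from compound 2 to compound 4; the limit leaves it open whether they differ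

Still open, from the compounds shown here alone, is what an ethyl group or a longer chain on the same carbonyl carbon would give in this assay, which would help show whether the vinyl group itself matters. The true size of either step also remains open, as both starting compounds rest on the same limit: the limit of > 100000 nM in this assay, at which 2 of the 4 values shown sit.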